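The compounds below may be only part of what the source reports. "The series", "measured", "known", "first", "only" and "open" are said of these compounds alone.

Measured in a functional assay on the whole organism for inhibition, with Mus musculus as the target, with stated times of 30 min and 2 h, at a dose of 10 mg/kg by the intraperitoneal route; a lower number here means less inhibition, a higher number more inhibition at the dose given (going by the name of the read-out):
compound 1 `O=C(NCc1ccc(CNS(=O)(=O)c2ccccc2)cc1)c1cccnc1` gives 53%
compound 2 `Cc1ccc(S(=O)(=O)NCc2ccc(CNC(=O)c3ccc(Cl)cc3)cc2)cc1` gives 50%
compound 3 `COc1ccccc1C(=O)NCc1ccc(CNS(=O)(=O)c2ccc(C)cc2)cc1` gives "not active" (no number reported)

Going by the values given here, compound 1 and compound 2 lie within the scatter of each other in this assay; compound 3 gives no number in this assay, so there is no measured step to lean on.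

Compound 4 `O=C(NCc1ccc(CNS(=O)(=O)c2ccccc2)cc1)c1c(Cl)cc(Cl)cc1Cl` is not yet measured. It differs from compound 1 in one place: 2,4,6-trichlorophenyl in place of pyridin-3-yl on a carbonyl carbon. No measured pair shows this change, and the three compounds shown carry three different groups on the carbonyl carbon with no common thread. The expected step from compound 1 to compound 4, a number 13 percentage points lower from compound 1 to compound 4 (beyond the scatter), is a modest loss, beyond the scatter only at its lower end. Compound 4 is estimated at 40%, with a range from 10% to 65%.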

Compound 4, a percentage reported as inhibition, in the whole organism at one dose (the size of the read-out at that dose, not a potency): "not active" (no number reported)
Compound 4 has no reported number here; there is nothing to compare the estimate with.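

In this assay, going by these compounds alone, compound 4 carries no number, so no step from compound 1 can be read. From the compounds shown here alone, whether 2,4,6-trichlorophenyl in place of pyridin-3-yl changes inhibition stays open. No measurement shown explains this result.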